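A few compounds are considered here, and "the series" means these few. Any claim that something is new, unique, unknown or untested is made for them only; others in the source may bear on it.

Measured in a functional assay on A549 cells (Homo sapiens) for antiproliferative activity, read by MTT assay, with a stated time of 48 h; on this read-out higher numbers stand for weaker inhibition and lower numbers for stronger inhibition:

- compound 1 `CC(C)=CCC[C@]1(C)/C=C/[C@@H](OC(=O)C=C(C)C)[C@](C)(O)/C=C/C(=O)/C(CN2CCN(C)CC2)=C\C1`: 940 nM
- compound 2 `COCOC/C1=C/C[C@](C)(CCC=C(C)C)/C=C/[C@@H](OC(=O)C=C(C)C)[C@](C)(O)/C=C/C1=O`: 2980 nM
- compound 3 `CC(C)=CCC[C@]1(C)/C=C/[C@@H](OC(=O)C=C(C)C)[C@](C)(O)/C=C/C(=O)/C(CN=[N+]=[N-])=C\C1`: 1720 nM

Compound 3 has the second highest of these three numbers, but it is not clearly separated from either neighbour. The two steps that reach it are a 1.8-fold higher number from compound 1 to compound 3 (0.26 log units; within the scatter) and a 1.7-fold lower number from compound 2 to compound 3 (0.24 log units; within the scatter). Compound 4 `CC(C)=CCC[C@]1(C)/C=C/[C@@H](OC(=O)C=C(C)C)[C@](C)(O)/C=C/C(=O)/C(C(=O)N(C)C)=C\C1` has not yet been measured. It is made from compound 3 by one structural change, dimethylcarbamoyl in place of azidomethyl on a double-bonded ring carbon.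

Among the measured compounds shown here, all the measured steps bear on this same part of the molecule, but each swaps only the group on the saturated chain carbon. The largest is modest: a 3.2-fold higher number from compound 1 to compound 2 (0.50 log units; beyond the scatter). The other two stay within the scatter. For the measured compounds named here, no measured compound carries dimethylcarbamoyl, and none lacks that saturated chain carbon, so these steps are only a rough guide. With that caution, no step beyond the scatter is expected in this assay, and a wide range is warranted. The expected result is a 1.2-fold higher number from compound 3 to compound 4 (0.07 log units; within the scatter). The estimate for compound 4 is 2000 nM, with an expected range from 700 nM to 5500 nM.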

Compound 4, half-maximal inhibitory concentration: 2700 nM
The estimate for compound 4 lay 1.4-fold (0.13 log units) below the measured number; the measured number falls inside the stated range.
By their numbers in this assay, from the lowest: compounds 1, 3, 4 and 2 (each within the scatter of the next, the first and the last beyond it).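

Moving from azidomethyl to dimethylcarbamoyl removes the saturated chain carbon and places a carbonyl directly on the double-bonded ring carbon, yet in this assay this larger change gives no clear shift (a 1.6-fold higher number from compound 3 to compound 4 (0.20 log units; within the scatter)), and the same holds against the methoxymethoxy-bearing compound (a 1.1-fold lower number from compound 2 to compound 4 (0.04 log units; within the scatter)). Compared with the (4-methylpiperazin-1-yl)methyl group, however, the dimethylcarbamoyl group gives a modest step beyond the scatter (a 2.9-fold higher number from compound 1 to compound 4 (0.46 log units; beyond the scatter)), which matches the earlier separation of compound 2 from compound 1, while compound 3 goes against any clean split because it stays within the scatter of compound 1. Nothing shown here gives a measured property or other evidence that would explain these differences.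

From the compounds shown here alone, it remains open whether the small gap to compound 1 comes from the 4-methylpiperazin-1-yl group or from the saturated chain carbon that carries it, which a 4-methylpiperazin-1-ylcarbonyl group on the same ring carbon could help separate. A carboxylic acid or a primary amide at this position would also show how far the dimethylamino part of the new group matters.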